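A few compounds are considered here, and "the series" means these few. Any claim that something is new, unique, unknown or untested is made for them only; others in the source may bear on it.

Of the two numbers reported in an assay on isolated protein for displacement of a labelled ligand from growth hormone secretagogue receptor type 1 (Homo sapiens), with a stated time of 1 h (on this read-out lower numbers stand for stronger inhibition and higher numbers for weaker inhibition), compound 3 `COC(=O)CCCn1nnnc1[C@@H](COCc1ccccc1)NC(=O)C(C)(C)N` gives the lower one, 2380 nM, though its gap to compound 2 lies within the scatter. Compound 2 `CC(C)(N)C(=O)N[C@H](COCc1ccccc1)c1nnnn1CCCCC#N` gives 3120 nM in this assay, and the step runs a 1.3-fold lower number from compound 2 to compound 3 (0.12 log units; within the scatter). For compound 1 `CC(C)(N)C(=O)N[C@H](COCc1ccccc1)c1nnnn1CCCCCNS(C)(=O)=O` this assay reports only a limit, > 5000 nM. Compound 4 `CC(C)(N)C(=O)N[C@H](COCc1ccccc1)c1nnnn1CCC(=O)NCc1ccccc1` differs from compound 3 in that (benzylcarbamoyl in place of (methoxycarbonyl)methyl on a saturated chain carbon, two bonds along the chain from an aromatic nitrogen). For the measured compounds named here, no measured step introduces a benzylcarbamoyl group; the nearest comparisons, an at least 2.1-fold lower number from compound 1 to compound 3 (0.32 log units; beyond the scatter) and an at least 1.6-fold lower number from compound 1 to compound 2 (0.20 log units; that floor lies within the scatter), rework the same chain, one beyond the scatter and at least modest, the other within it. Compound 4 is therefore expected to move little, a 1.2-fold lower number from compound 3 to compound 4 (0.08 log units; within the scatter). In this assay compound 4 is estimated at 2000 nM, within a range from 700 nM to 6000 nM.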

Compound 4, inhibition constant: 1070 nM
Compound 4: middle estimate off by 1.9-fold (0.27 log units), on the high side; measured number inside the range.
By their numbers in this assay, from the lowest: compound 4; then compounds 3 and 2 (each within the scatter of the next). At a limit, above all of these: compound 1.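

Benzylcarbamoyl, on a saturated chain carbon two bonds along the chain from an aromatic nitrogen, clears the scatter against both measured neighbours, a 2.2-fold lower number from compound 3 to compound 4 (0.35 log units; beyond the scatter) and a 2.9-fold lower number from compound 2 to compound 4 (0.46 log units; beyond the scatter), whereas the step between those two neighbours stayed within it. Compound 1 is held only at a limit: the limit of > 5000 nM in this assay, at which 1 of the 4 values shown sits. Against that limit the step reads an at least 4.6-fold lower number from compound 1 to compound 4 (0.66 log units; beyond the scatter).

Left open is whether the six-membered aromatic ring or the carbamoyl part carries this step. Also open, as far as these compounds go, is how a methylcarbamoyl group, a carboxylic acid or a longer chain would read at this place.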